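Estimating compound 4: 2,2-dimethyl-1,3-dioxolan-4-yl replacing 1,2-dihydroxyethyl

The source may hold more compounds than are shown below. What is called first, only, known or untested is meant among the compounds shown, and "the series" means these compounds.

In a functional assay on A549 cells (Homo sapiens) for cytotoxicity, read by MTT assay, with a stated time of 72 h (a higher number here means a weaker inhibitor, a lower number a stronger inhibitor), compound 2 `O=C1c2c[n+]([O-])c3ccccc3c2C(=O)c2c1c1ccccc1n2Cc1cn(CC(O)CO)nn1` gives 880 nM. That places it at the weak end of the three measured compounds, alongside compound 3 `O=C1c2c[n+]([O-])c3ccccc3c2C(=O)c2c1c1ccccc1n2CCCCN1CCNCC1` at 540 nM, with a 1.6-fold lower number from compound 2 to compound 3 (0.21 log units; within the scatter). Compound 1 `CC1(C)OCC(Cn2cc(Cn3c4c(c5ccccc53)C(=O)c3c[n+]([O-])c5ccccc5c3C4=O)nn2)O1` stands well apart at 80 nM.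

Compound 4 `CC1(C)OC[C@@H](Cn2cc(Cn3c4c(c5ccccc53)C(=O)c3c[n+]([O-])c5ccccc5c3C4=O)nn2)O1` has not yet been measured. It differs from compound 2 as follows: 2,2-dimethyl-1,3-dioxolan-4-yl in place of 1,2-dihydroxyethyl on a saturated chain carbon bound to an aromatic nitrogen. In words, 2,2-dimethyl-1,3-dioxolan-4-yl sits in place of 1,2-dihydroxyethyl on a saturated chain carbon bound to an aromatic nitrogen.

The measured step that bears on this is an 11-fold higher number from compound 1 to compound 2 (1.04 log units; beyond the scatter), which exchanged the same two groups in the opposite direction. A large step of similar size, toward a lower number and so a stronger inhibitor, is therefore expected in this assay. The step to compound 3 replaces a different group and offers little guidance here. The entering group in compound 4 has a defined stereocentre, and the data hold no measurement of what that contributes, so the range is kept generous. The estimated change is a 10-fold lower number from compound 2 to compound 4 (1.02 log units; beyond the scatter). For compound 4 the expected value is 85 nM, with an estimated range from 40 nM to 180 nM.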

Compound 4, half-maximal inhibitory concentration: 4700 nM
Estimate against measurement, compound 4: 55-fold (1.74 log units) below; measured number outside the range, above it.
By their numbers in this assay, from the lowest: compound 1; then compounds 3 and 2 (each within the scatter of the next); then compound 4.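

In this assay, putting 2,2-dimethyl-1,3-dioxolan-4-yl in place of 1,2-dihydroxyethyl on a saturated chain carbon bound to an aromatic nitrogen gives a 5.3-fold higher number from compound 2 to compound 4 (0.73 log units; beyond the scatter), while the reverse exchange starting from the ring in compound 1 gave an 11-fold higher number from compound 1 to compound 2 (1.04 log units; beyond the scatter), so the same pair of groups now moves the number in the other direction. The name of the ring alone therefore does not settle the result at this position, as two compounds with the same atoms and bonds lie far apart, with a 59-fold higher number from compound 1 to compound 4 (1.77 log units; beyond the scatter). Going by these compounds alone, only one difference between that pair is on record, and the gap can be traced to nothing else: the fact that one of compounds 1 and 4 is drawn with a defined configuration and the other without, at the place where they differ.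

The compounds shown leave open what compound 1 holds at its undrawn stereocentre and how the S form of the ring, the mirror image of the R form in compound 4, would read in this assay. They also leave open how a carboxylic acid or a longer chain carrying the same ring would compare at this position.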